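This account rests on a few compounds, and the source may have more. Where it says the series, first, only, none or still open, it means among the compounds named here.

Measured so far in an ADME assay on MT2 cells (Homo sapiens) for cytotoxicity; on this read-out higher numbers stand for lower toxicity in this test and lower numbers for higher toxicity in this test:
compound 1 `Cc1cc(C#N)cc(C)c1Oc1cc(Nc2ccc(C#N)cc2)c(N)cc1CO` — 122000 nM
compound 2 `Cc1cc(C#N)cc(C)c1Oc1cc(Nc2ccc(C#N)cc2)c(N)cc1CN1CCN(C)CC1` — 96900 nM

Compound 1 stands highest of the two numbers in this assay; the nearest is compound 2, at a 1.3-fold lower number from compound 1 to compound 2 (0.10 log units; within the scatter), so the two compounds are not separated on this read-out.

Compound 3 `Cc1cc(C#N)cc(C)c1Oc1cc(Nc2ccc(C#N)cc2)c(N)cc1COC(C)C` differs from compound 1 by isopropyl in place of hydrogen on an oxygen on a saturated carbon; read one bond further out, hydroxymethyl becomes isopropoxymethyl.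

Among the compounds with values here, the only measured step, from compound 1 to compound 2, changes the same hydroxymethyl group, putting 4-methylpiperazin-1-yl in place of hydroxy, and it stayed within the scatter. Within the data shown here, no measured step exchanges the hydrogen on that oxygen for isopropyl, so there is no direct precedent, but the one change made at this position left this assay unmoved.

For compound 3 the expected step is therefore a 1.1-fold lower number from compound 1 to compound 3 (0.04 log units; within the scatter), none beyond the scatter. Compound 3 is estimated at 110000 nM, with a range of 50000 nM to 240000 nM.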

Compound 3, half-maximal cytotoxic concentration: 89400 nM
Estimate against measurement, compound 3: 1.2-fold (0.09 log units) above, and the stated range covers the measured number.
By their numbers in this assay, from the lowest: compounds 3, 2 and 1 (each within the scatter of the next).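

Isopropyl in place of hydrogen on the oxygen gives, in this assay, a 1.4-fold lower number from compound 1 to compound 3 (0.14 log units; within the scatter) and so does not separate the isopropoxymethyl compound from the hydroxymethyl parent. Isopropoxy in place of 4-methylpiperazin-1-yl gives a 1.1-fold lower number from compound 2 to compound 3 (0.03 log units; within the scatter) in this assay, so hydroxy, 4-methylpiperazin-1-yl and isopropoxy on this saturated chain carbon are not separated on this read-out, and no compound shown goes against that. No supporting data are available to explain this result.

As far as these compounds go, whether a carboxylic acid, a primary amine or a longer alkoxy chain on the same carbon would give a step beyond the scatter remains open. Also open, from the compounds shown here alone, is whether changes elsewhere on the shared core would leave this read-out equally unresolved.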